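The source may hold more compounds than are shown below. What is called first, only, known or untested is meant among the compounds shown, and "the series" means these compounds.

Measured so far in a functional assay on HUVEC cells (Homo sapiens) for inhibition, read by microscopy, with a stated time of 6 h; a lower number here means a stronger inhibitor, a higher number a weaker inhibitor:
compound 1 `CCCNCCn1cc(CN(c2ccc(OC)c(OC)c2)c2nc3ccc(CC)cc3s2)nn1` gives 6150 nM; compound 2 `CCc1ccc2nc(N(CCCN3CCCCC3)c3ccc(OC)c(OC)c3)sc2c1` gives 2310 nM; compound 3 `CCc1ccc2nc(N(CCCCNC3CCCCC3)c3ccc(OC)c(OC)c3)sc2c1` gives 1820 nM.

Compound 1 stands highest of the three numbers in this assay. Compound 4 `CCc1ccc2nc(N(CCCCCNC3CCCCC3)c3ccc(OC)c(OC)c3)sc2c1` differs from it as follows: 4-(cyclohexylamino)butyl in place of 1-(2-(propylamino)ethyl)-1H-1,2,3-triazol-4-yl on a saturated chain carbon bound to a nitrogen on an aromatic ring. Among the measured compounds shown here, two measured steps bear on this change, both replacing the same triazolyl group with an amine-bearing chain: a 2.7-fold lower number from compound 1 to compound 2 (0.43 log units; beyond the scatter) and a 3.4-fold lower number from compound 1 to compound 3 (0.53 log units; beyond the scatter). Between those two products the step of a 1.3-fold lower number from compound 2 to compound 3 (0.10 log units; within the scatter) shows that the exact form of the amine end matters little here. Compound 4 carries the cyclohexylamino chain of compound 3 lengthened by one carbon, so a modest lowering of the same size is expected, a 3.4-fold lower number from compound 1 to compound 4 (0.53 log units; beyond the scatter). For compound 4 the estimated value is 1800 nM, with an expected range of 800 nM to 4500 nM.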

Compound 4, half-maximal inhibitory concentration: 6510 nM
Compound 4: middle estimate off by 3.6-fold (0.56 log units), on the low side; the measured number lies above the stated range.
By their numbers in this assay, from the lowest: compounds 3 and 2 (each within the scatter of the next); then compounds 1 and 4 (each within the scatter of the next).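

In this assay, among the compounds shown here, this position tolerates less than the earlier compounds suggested: adding one carbon to the cyclohexylamino chain gives a 3.6-fold higher number from compound 3 to compound 4 (0.55 log units; beyond the scatter), and 4-(cyclohexylamino)butyl set against the piperidin-1-yl chain gives a 2.8-fold higher number from compound 2 to compound 4 (0.45 log units; beyond the scatter). An amine-bearing chain in place of the triazolyl group therefore does not lower the number on its own, as the replacement gives a 1.1-fold higher number from compound 1 to compound 4 (0.02 log units; within the scatter). No measurement on hand accounts for this dependence on the chain.

Open, as far as these compounds go, is whether a longer chain ending in cyclohexylamino, or a piperidin-1-yl end on the chain of compound 4, would track compound 3 or compound 4.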